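A few compounds are considered here, and "the series" means these few. Any claim that something is new, unique, unknown or untested is made for them only; others in the source may bear on it.

Series notes. Compound 1 `COc1cc(Br)c(-c2nc3ccccc3[nH]2)cc1OC` serves as the reference point of this small set. In an assay for inhibition of Alpha amylase (Homo sapiens), with a stated time of 10 min (on this read-out lower numbers stand for stronger inhibition and higher numbers for weaker inhibition), compound 1 gives 1510 nM. Compound 3 `COc1cccc(-c2nc3cc(F)ccc3[nH]2)c1Cl` gives 2620 nM in this assay, and compound 2 `COc1cccc(-c2nc3cc(C)c(C)cc3[nH]2)c1Cl` gives 2840 nM. Compound 1 thus carries the lowest of the three numbers, but its pair with compound 3 and its pair with compound 2 both sit within the scatter of repeated measurements, so no order among the three can be read from these values. Among the compounds with values here, the three compounds differ from one another in more than one place, and no pair isolates a single change.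

Compound 4 `COc1cc(Br)c(-c2nc3cc(Cl)ccc3[nH]2)cc1OC` is the next compound to be measured. Relative to compound 1 the change is chloro in place of hydrogen on an aromatic carbon. Within the data shown here, the measured set holds no pair that isolates a chloro for hydrogen exchange on the core, so the step has no measured precedent here. The expected step is a 1.3-fold lower number from compound 1 to compound 4 (0.10 log units; within the scatter), most likely not beyond the scatter, with a slight lean toward a lower number. For compound 4 the expected value in this assay is 1200 nM, within a range from 500 nM to 3000 nM.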

Compound 4, half-maximal inhibitory concentration: 1730 nM
For compound 4 the middle estimate is 1.4-fold (0.16 log units) below the measured one; low and high end bracket the measured number.
By their numbers in this assay, from the lowest: compounds 1, 4, 3 and 2 (each within the scatter of the next).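

Working notes, chloro step. In this assay, within the data shown here, this pair is the first in the set to isolate a single change, and it gives a 1.1-fold higher number from compound 1 to compound 4 (0.06 log units; within the scatter) for chloro in place of hydrogen on an aromatic carbon. The step lies within the scatter, so on this read-out compound 1 and compound 4 cannot be told apart, and this position, on a six-membered aromatic ring of carbon only and part of a fused system of two rings, carries a chloro with no separable shift in the number. No measured evidence bears on why the exchange leaves the number within the scatter.

Still open, as far as these compounds go, is whether a group of another kind at this position, such as an amine or a carboxylic acid, would give a step beyond the scatter on the core of compound 1. Also open, from the compounds shown here alone, is whether the chloro for hydrogen exchange would read the same on a core other than that of compound 1, since this single pair speaks only for that core.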